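The compounds below may be only part of what the source reports. "The series", "measured", "known", "first", "only" and "open" are said of these compounds alone.

Measured so far:
- compound 1, `[N-]=[N+]=NCc1ncnc2c1ncn2[C@@H]1O[C@H](CO)[C@@H](O)[C@H]1O`: > 250000 nM
- compound 2, `OC[C@H]1O[C@@H](n2cnc3c(COc4ccccn4)ncnc32)[C@H](O)[C@@H]1O`: > 250000 nM

In a functional assay on Huh-7 cells (Homo sapiens) for cytotoxicity, read by MTT assay, with a stated time of 3 days (a lower number here means that less compound is tolerated, a higher number that more compound is tolerated), compound 1 gives > 250000 nM, which is a limit of the assay and not a number. Compound 2, in which (pyridin-2-yl)oxy replaces azido on a saturated chain carbon bound to an aromatic carbon, also gives only a limit, > 250000 nM. The step that the two limits leave unreadable from compound 1 to compound 2 is therefore not readable, since (the limit of > 250000 nM in this assay, at which 2 of the 2 values shown sit).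

Compound 3, `OCCSCc1ncnc2c1ncn2[C@@H]1O[C@H](CO)[C@@H](O)[C@H]1O`, is not yet measured. It differs from compound 1 by (2-hydroxyethyl)sulfanyl in place of azido on a saturated chain carbon bound to an aromatic carbon. Only the unreadable step from compound 1 to compound 2 bears on this change, and it shows no size at all, so no direction can be drawn from it. Compound 3 is expected to remain at the limit as well, with an estimate of 300000 nM in this assay and a range from 120000 nM to 1000000 nM. The expected step is a step that the limit leaves unreadable from compound 1 to compound 3, essentially none beyond the scatter.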

Compound 3, half-maximal cytotoxic concentration: > 100000 nM
Compound 3: no number, only a limit; the forecaster's own chance of this, stated with the estimate: 85%; the middle value does not contradict the limit.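

In this assay compound 3 gives > 100000 nM, which is a limit of the assay and not a number. The steps among compound 1, compound 2 and compound 3 therefore cannot be read. The compounds shown leave open whether any of these groups on the shared core changes the tolerated concentration at all.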